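The source may report more compounds than this note shows. Statements on the series, on what has been measured and on what is new or still open speak of the compounds shown alone.

Measured compounds in a functional assay, with a stated time of 6 min; on this read-out higher numbers stand for weaker inhibition and lower numbers for stronger inhibition:

compound 1, `CCOc1ccccc1NCn1nc(-c2ccc3c(c2)OCCO3)oc1=S`, 5280 nM
compound 2, `CCCCCCCCCCCCCCCCNCn1nc(-c2ccc3c(c2)OCCO3)oc1=S`, 22900 nM
compound 3, `Fc1cc(NCn2nc(-c3ccc4c(c3)OCCO4)oc2=S)cc(F)c1F`, 2920 nM

Compound 1 stands second highest of these three numbers. Its nearest neighbour is compound 3, reached by a 1.8-fold lower number from compound 1 to compound 3 (0.26 log units; within the scatter), a step the scatter covers; the change there is 3,4,5-trifluorophenyl in place of 2-ethoxyphenyl on an amine nitrogen. Compound 2 lies furthest away, and its value shows a higher number than compound 1 by a gap beyond the scatter.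

Compound 4, `S=c1oc(-c2ccc3c(c2)OCCO3)nn1CNc1ccc(Cl)cc1Cl`, has not yet been measured. It differs from compound 1 in one place: 2,4-dichlorophenyl in place of 2-ethoxyphenyl on an amine nitrogen. Within the data shown here, the one measured step that bears on this, from compound 1 to compound 3, also replaced 2-ethoxyphenyl with a halogen-bearing phenyl group on the amine nitrogen and stayed within the scatter. A step of similar size, toward a somewhat lower number or none beyond the scatter, is therefore expected in this assay. Compound 4 is expected to give 3500 nM, with a range from 1200 nM to 10000 nM. This estimate means an expected 1.5-fold lower number from compound 1 to compound 4 (0.18 log units; within the scatter).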

Compound 4, half-maximal inhibitory concentration: 8710 nM
Beside the measured number, compound 4's estimate is 2.5-fold (0.40 log units) below it; the measured number falls inside the stated range.
By their numbers in this assay, from the lowest: compounds 3, 1 and 4 (each within the scatter of the next, the first and the last beyond it); then compound 2.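

In this assay, 2,4-dichlorophenyl on the amine nitrogen gives a 1.6-fold higher number from compound 1 to compound 4 (0.22 log units; within the scatter), so this change, like the earlier one to 3,4,5-trifluorophenyl, cannot be told apart from 2-ethoxyphenyl. Among these compounds, the two halogen-bearing phenyl groups, however, can be told apart from each other, with a 3.0-fold higher number from compound 3 to compound 4 (0.47 log units; beyond the scatter), a modest step and the first between phenyl groups at this position to lie beyond the scatter. Nothing available accounts for this difference between the two groups.

The compounds shown leave open whether the kind of halogen, the number of halogens or their placement on the phenyl ring carries this step. They also leave open how a phenyl group bearing a carboxylic acid or an amine, or a shorter saturated chain, would read at this position.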